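The source may hold more compounds than are shown below. What is called first, only, known or untested is meant among the compounds shown, and "the series" means these compounds.

In an ADME assay on U2OS cells (Homo sapiens) for cytotoxicity (a lower number here means that less compound is tolerated, a higher number that more compound is tolerated), compound 3 `O=C(N/N=C/c1ccc([N+](=O)[O-])o1)C1CCCCC1` gives 25400 nM, the higher of the two numbers recorded. Compound 1 `CCCCNc1ccc(C(=O)N/N=C/c2ccc([N+](=O)[O-])o2)cc1` gives 12000 nM in this assay. For compound 2 `CCCCCCC1CCC(C(=O)N/N=C/c2ccc([N+](=O)[O-])o2)CC1` the assay reports only a limit, > 200000 nM. Among the compounds with values here, the single step measured in one place, an at least 7.8-fold lower number from compound 2 to compound 3 (0.89 log units; beyond the scatter), removes a hexyl from the saturated ring and does not touch the ring itself. Compound 4 `CCCCCC(=O)N/N=C/c1ccc([N+](=O)[O-])o1` differs from compound 3 in that place: pentyl in place of cyclohexyl on a carbonyl carbon. Within the data shown here, no measured step matches this change, and the one step recorded concerns a different part of the molecule, so it offers little guidance. Compound 3 and compound 4 are therefore expected to lie close together, with a step of a 1.3-fold lower number from compound 3 to compound 4 (0.10 log units; within the scatter) in this assay that stays within the scatter. Compound 4 is expected to give 20000 nM, between 7000 nM and 60000 nM.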

Compound 4, half-maximal cytotoxic concentration: 19300 nM
The estimate for compound 4 lay 1.0-fold (0.02 log units) above the measured number; measured number inside the range.
By their numbers in this assay, from the lowest: compounds 1, 4 and 3 (each within the scatter of the next, the first and the last beyond it). At a limit, above all of these: compound 2.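

In this assay, the change on the carbonyl carbon, a 1.3-fold lower number from compound 3 to compound 4 (0.12 log units; within the scatter), stays within the scatter, so compound 3 and compound 4 cannot be told apart. At this position, then, an open pentyl chain serves as well as the cyclohexyl ring, and for these two compounds the ring is not needed for a number of this size. Nothing given here explains this result.

From the compounds shown here alone, it remains open whether a methyl or a longer chain such as decyl on this carbonyl carbon would give a similar number. The same holds for an amine or a carboxylic acid at the end of the pentyl chain.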